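From Allyl to Phenyl: What Compound 4 Might Show

A few compounds are considered here, and "the series" means these few. Any claim that something is new, unique, unknown or untested is made for them only; others in the source may bear on it.

Compound 1 `N=C(N)N/N=C\c1ccccc1OCc1ccc2no[n+]([O-])c2c1` gives 58 uM
Compound 2 `NC(=S)N/N=C\c1ccccc1OCc1ccc2no[n+]([O-])c2c1` gives 189 uM
Compound 3 `C=CCNC(=S)N/N=C\c1ccccc1OCc1ccc2no[n+]([O-])c2c1` gives 139 uM

All three values come from an ADME assay on cells (Erythrocyte, Homo sapiens), read by spectrophotometry and hemolysis, with a stated time of 24 h (a higher number here means a weaker inhibitor, a lower number a stronger inhibitor), and compound 3 stands among the higher numbers of this small set. Within the data shown here, the data show a 2.4-fold higher number from compound 1 to compound 3 (0.38 log units; beyond the scatter) and also a 1.4-fold lower number from compound 2 to compound 3 (0.13 log units; within the scatter), so it is clearly separated from only one of its two neighbours.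

Compound 4 `[O-][n+]1onc2ccc(COc3ccccc3/C=N\NC(=S)Nc3ccccc3)cc21` has not yet been measured. Its difference from compound 3 is phenyl in place of allyl on an amide-type nitrogen and in words it carries phenyl in place of allyl on an amide-type nitrogen, whose other neighbour is the thiocarbonyl carbon.

Among the measured compounds shown here, only one measured step touches that same nitrogen: a 1.4-fold lower number from compound 2 to compound 3 (0.13 log units; within the scatter), which put allyl in place of hydrogen. The modest 3.3-fold higher number from compound 1 to compound 2 (0.51 log units; beyond the scatter) replaces a different group and says little about this change. For the measured compounds named here, no compound with phenyl has been measured, so the evidence is thin. In this assay a step beyond the scatter is not expected, in either direction. The estimated move is a 1.1-fold lower number from compound 3 to compound 4 (0.05 log units; within the scatter) and it is expected to stay small. Compound 4 is expected near 125 uM as a central value. The estimated range for compound 4 runs from 55 uM to 280 uM on this reasoning.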

Compound 4, concentration for 50% inhibition: > 200 uM
Compound 4 gave a limit, no number (the forecaster's own chance of this, stated with the estimate: 10%); at least 1.6-fold (0.20 log units) between middle value and limit.
By their numbers in this assay, from the lowest: compound 1; then compounds 3 and 2 (each within the scatter of the next). At a limit, above all of these: compound 4.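

In this assay compound 4 gives a limit and not a number: the limit of > 200 uM in this assay, at which 1 of the 4 values shown sits. Until now the nitrogen whose other neighbour is the thiocarbonyl carbon had carried only hydrogen and allyl, and phenyl brings the first ring to this place, yet the steps that can be read are only floors: an at least 1.4-fold higher number from compound 3 to compound 4 (0.15 log units; that floor lies within the scatter) and an at least 1.0-fold higher number from compound 2 to compound 4 (0.02 log units; that floor lies within the scatter). The one floor that clears the scatter is an at least 3.4-fold higher number from compound 1 to compound 4 (0.53 log units; beyond the scatter), so swapping allyl or hydrogen for phenyl is not yet shown to matter on its own, while compound 4 is clearly separated from compound 1, as compound 2 and compound 3 already were.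

As far as these compounds go, with only a limit for compound 4, the true size of the change from allyl to phenyl stays open. Also open, from the compounds shown here alone, is how benzyl, cyclohexyl, a longer chain or a phenyl ring carrying an amine or a carboxylic acid would read on this nitrogen, and so whether an aromatic ring matters here or simply a larger carbon group.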